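Working notes on cytotoxicity: compound 2 to compound 4

A few compounds are considered here, and "the series" means these few. Any claim that something is new, unique, unknown or untested is made for them only; others in the source may bear on it.

Measured so far:
compound 1 `CCCCCCCCCCCCCCNC(=O)[C@H](CO)/N=C/c1cccc(OC)c1`: 31300 nM
compound 2 `CCCCCCCCCCCCCCNC(=O)[C@H](CO)/N=C/c1ccccc1[N+](=O)[O-]`: 21700 nM
compound 3 `CCCCCCCCCCCCCCNC(=O)[C@H](CO)/N=C/c1ccccc1C`: 87700 nM

In a functional assay on cells (Homo sapiens) for cytotoxicity, read by MTT assay, with a stated time of 24 h (a lower number here means a stronger inhibitor, a higher number a weaker inhibitor), compound 2 gives the lowest of the three numbers. Its nearest neighbour is compound 1, with a 1.4-fold lower number from compound 1 to compound 2 (0.16 log units; within the scatter), so the two cannot be ordered. Its furthest neighbour is compound 3, with a 4.0-fold higher number from compound 2 to compound 3 (0.61 log units; beyond the scatter), a modest step and the only one here beyond the scatter together with a 2.8-fold higher number from compound 1 to compound 3 (0.45 log units; beyond the scatter).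

Compound 4 `CCCCCCCCCCCCCCNC(=O)[C@H](CO)/N=C/c1cccc(O)c1` is not yet measured. It differs from compound 2 as follows: 3-hydroxyphenyl in place of 2-nitrophenyl on a carbon with a double bond to nitrogen.

For the measured compounds named here, no measured step swaps 2-nitrophenyl for 3-hydroxyphenyl, and no measured step swaps methoxy for hydroxy on the aromatic carbon. Going by the values given here, the step that bears most on it is the one between compound 1 and compound 2, a 1.4-fold lower number from compound 1 to compound 2 (0.16 log units; within the scatter), which moved within the scatter when 3-methoxyphenyl stood in place of 2-nitrophenyl; compound 4 carries a related 3-substituted ring. The two steps beyond the scatter both involve 2-methylphenyl and do not concern compound 4 directly. The expectation is therefore a small step upward, likely within the scatter, a 1.4-fold higher number from compound 2 to compound 4 (0.14 log units; within the scatter).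

Compound 4 is expected to give 30000 nM in this assay, within a range of 12000 nM to 80000 nM.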

Compound 4, half-maximal inhibitory concentration: 32600 nM
Beside the measured number, compound 4's estimate is 1.1-fold (0.04 log units) below it, within the range that was stated.
By their numbers in this assay, from the lowest: compounds 2, 1 and 4 (each within the scatter of the next); then compound 3.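

Read in this assay, the step that only puts hydrogen in place of methyl on the oxygen on the aromatic ring, a 1.0-fold higher number from compound 1 to compound 4 (0.02 log units; within the scatter), gives the series its first direct look at this change, and the two groups cannot be ordered. The wider swap to 3-hydroxyphenyl in place of 2-nitrophenyl, a 1.5-fold higher number from compound 2 to compound 4 (0.18 log units; within the scatter), also stays within the scatter although a hydrogen-bond donor enters, while 3-hydroxyphenyl in place of 2-methylphenyl, a 2.7-fold lower number from compound 3 to compound 4 (0.43 log units; beyond the scatter), lies beyond it, so among these four compounds only compound 3 stands apart from the others, with compound 1, compound 2 and compound 4 forming one level. Nothing measured alongside these numbers bears on why the steps fall as they do.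

Open, from the compounds shown here alone, is whether an amine or a carboxylic acid on the ring would stay at the level of compound 1, compound 2 and compound 4 or move away from it as compound 3 does. Also open, going by these compounds, is whether that level depends on the long chain on the amide, which is common to all four compounds and which a shorter chain would test.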